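Imidazole in place of cyclohexenyl: an antiproliferative estimate

The source may hold more compounds than are shown below. What is called first, only, known or untested is meant among the compounds shown, and "the series" means these compounds.

Measured in a functional assay on PC-3 cells (Homo sapiens) for antiproliferative activity, read by CCK-8 assay, with a stated time of 6 days (on this read-out higher numbers stand for weaker inhibition and lower numbers for stronger inhibition), as follows
Compound 1 `CCN(c1ccc(C#N)c(Cl)c1)c1cc(-n2cnc3ccccc32)ccc1C` gives 8160 nM
Compound 2 `CCN(c1ccc(C#N)c(Cl)c1)c1cc(C2=CCCCC2)ccc1C` is recorded as "not determined" (no result reported)

Going by the values given here, compound 2 therefore stands nowhere on the numbers, since no value exists for it in this assay and the only figure for comparison comes from compound 1. Compound 3 `CCN(c1ccc(C#N)c(Cl)c1)c1cc(-n2ccnc2)ccc1C` differs from compound 2 in one place, with 1H-imidazol-1-yl in place of cyclohex-1-en-1-yl on an aromatic carbon while the rest stays the same. Among the compounds with values here, no step from compound 2 can be sized, so the expectation rests on compound 1 at 8160 nM as the sole anchor. A result for compound 3 is expected to lie near that of compound 1, with no gap beyond the usual scatter and no direction that the data can fix. For compound 3 the expected value is 6000 nM within an estimated range of 1500 nM to 20000 nM in this measurement.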

Compound 3, half-maximal inhibitory concentration: > 30000 nM
Compound 3 was reported as a limit; the forecaster's own chance of this, stated with the estimate: 15%; at least 5.0-fold (0.69 log units) between middle value and limit.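

Putting 1H-imidazol-1-yl in place of 1H-benzimidazol-1-yl on this aromatic carbon, para to a methyl group, gives an at least 3.6-fold higher number from compound 1 to compound 3 (0.56 log units; beyond the scatter) in this assay. The shared core therefore does not carry its activity alone, and the result in this assay depends on which of these two groups sits at this position. The figure for compound 3 is a limit and not a number: the limit of > 30000 nM in this assay, at which 1 of the 3 values shown sits.

Compound 2 has no value, so the step from compound 2 to compound 3 cannot be read, and cyclohex-1-en-1-yl cannot be placed against either of the other two groups. The compounds shown leave open whether an amine such as morpholine, or a plain phenyl ring, at this position would stand closer to compound 1 or to compound 3 in this assay.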